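A few compounds are considered here, and "the series" means these few. Any claim that something is new, unique, unknown or untested is made for them only; others in the source may bear on it.

In a functional assay on MDA-MB-468 cells (Homo sapiens) for antiproliferative activity (a lower number here means a stronger inhibitor of growth, a higher number a weaker inhibitor of growth), compound 1 (`Oc1ccc(-c2nc3ccccc3s2)cc1O`) gives 220 nM. Going by the values given here, the only other measured member of the series, compound 2 (`COc1ccc(-c2nc3cc(F)ccc3s2)cc1I`), gives 360 nM, and these two values lie within the scatter of each other. Compound 3 (`Oc1ccc(-c2nc3cc(F)ccc3s2)cc1O`) keeps the core of compound 1 and carries one change, fluoro in place of hydrogen on an aromatic carbon. Compound 2 also carries the fluoro group but differs from compound 3 elsewhere, so the two measured values do not isolate this change. Among the compounds with values here, no measured step in this assay covers it either. A shift no larger than the scatter is expected, with no firm direction. The estimated step is a 1.1-fold lower number from compound 1 to compound 3 (0.04 log units; within the scatter). Compound 3 is estimated at 200 nM, with an expected range from 70 nM to 600 nM.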

Compound 3, concentration for 50% growth inhibition: 190 nM
Estimate against measurement, compound 3: 1.1-fold (0.02 log units) above; the range from low to high includes it.
By their numbers in this assay, from the lowest: compounds 3, 1 and 2 (each within the scatter of the next).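

The pair of compound 1 and compound 3 isolates fluoro in place of hydrogen on an aromatic carbon, which the earlier values could not do, and in this assay the step is a 1.2-fold lower number from compound 1 to compound 3 (0.06 log units; within the scatter) with the rest of the structure unchanged. This position, on a six-membered aromatic ring of carbon only that is part of a fused system, therefore accepts fluoro with no shift beyond the scatter in growth inhibition. No accompanying measurement bears on the reason for this result.

Fluoro is the only replacement for hydrogen shown at this position, so the effect of an amine, a carboxylic acid or a longer chain there remains open. Going by these compounds alone, compound 2 differs from compound 3 in more than one place, so no step between them can be read.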